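The source may report more compounds than this note shows. Statements on the series, on what has been measured and on what is new or still open speak of the compounds shown alone.

Compound 1 `Cc1nc(NC(=O)c2ccccc2)c2nn(-c3ccccc3)cc2n1` gives the highest of the three numbers measured in an assay on CHO cells for displacement of a labelled ligand from adenosine receptor A1 (Homo sapiens), read by scintillation counting, with a stated time of 120 min, tested at 1 uM (a lower number here means less inhibition, a higher number more inhibition at the concentration tested (going by the name of the read-out)), at 30%. Compound 3 `COc1ccc(-n2cc3nc(C)nc(NC(=O)c4ccco4)c3n2)cc1` gives 6% in this assay, and compound 2 `COc1ccc(-n2cc3nc(-c4ccccc4)nc(NC(C)=O)c3n2)cc1` gives 1%; both of these lie beyond the usual scatter below compound 1. Going by the values given here, none of these three differs from another in only one place, so no single-change step is known from the measurements. Compound 4 `Cc1nc(NC(=O)c2cccnc2)c2nn(-c3ccccc3)cc2n1` differs from compound 1 in one place: pyridin-3-yl in place of phenyl on a carbonyl carbon. The rest of the structure is kept. Among the compounds with values here, no comparable step has been measured, so the step of a number 5 percentage points lower from compound 1 to compound 4 (within the scatter) that is expected here is small, in either direction, and not beyond the scatter. Compound 4 is expected to give about 25% in this assay, within a range from 5% to 50%.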

Compound 4, a percentage reported as inhibition, at one concentration (the size of the read-out at that concentration, not a potency): 12%
Compound 4: middle estimate off by 13 percentage points, on the high side; low and high end bracket the measured number.
By their numbers in this assay, from the lowest: compounds 2, 3 and 4 (each within the scatter of the next, the first and the last beyond it); then compound 1.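

Within this assay, the group on the carbonyl carbon turns out to matter: pyridin-3-yl in place of phenyl gives a number 18 percentage points lower from compound 1 to compound 4 (beyond the scatter) as the first single-change step available. The two groups have the same number of heavy atoms, yet replacing one ring carbon with nitrogen, which adds a hydrogen-bond acceptor, is enough to move the number. No evidence on the cause of this fall is available.

From the compounds shown here alone, whether a non-aromatic ring such as cyclohexyl on the same carbonyl carbon would keep or lower the number remains open. So does whether this swap would give a similar step with the rest of the structure changed.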